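Removing one methoxy group from compound 2

The source may hold more compounds than are shown below. What is called first, only, known or untested is meant among the compounds shown, and "the series" means these compounds.

Compounds measured so far:
compound 1 `COc1ccc(-c2cc(/C=C/C(=O)c3ccc(N)cc3)[nH]n2)cc1` gives -70%
compound 2 `COc1cc(-c2cc(/C=C/C(=O)c3ccc(N)cc3)[nH]n2)cc(OC)c1OC` gives -59%

In a functional assay on NCI-H460 cells (Homo sapiens) for cytotoxicity, read by sulforhodamine B assay, with a stated time of 48 h, tested at 100 uM (on this read-out higher numbers stand for a weaker effect at the one concentration tested and lower numbers for a stronger effect), compound 2 holds the highest of the two numbers; compound 1 sits below it, and the gap between compound 1 and compound 2 is beyond the scatter. Compound 3 `COc1ccc(-c2cc(/C=C/C(=O)c3ccc(N)cc3)[nH]n2)cc1OC` has not yet been measured. It arises from compound 2 by the change (hydrogen in place of methoxy on an aromatic carbon). Among the measured compounds shown here, with no measured step of this kind to lean on, only a small downward shift, within the scatter, is expected, a number 6 percentage points lower from compound 2 to compound 3 (within the scatter), resting on compound 1 at -70% and compound 2 at -59%. Compound 3 is therefore estimated at -65%, with a range from -82% to -48%.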

Compound 3, a percentage reported as activity, at one concentration (the size of the read-out at that concentration, not a potency): -76%
Compound 3: middle estimate off by 11 percentage points, on the high side; the range from low to high includes it.
By their numbers in this assay, from the lowest: compounds 3 and 1 (each within the scatter of the next); then compound 2.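

In this assay, hydrogen in place of this methoxy group gives a stronger effect, with a number 17 percentage points lower from compound 2 to compound 3 (beyond the scatter), so the group's presence at this position matters on the three-methoxy ring. The other pair behaves differently: methoxy in place of hydrogen on an aromatic carbon gives a number 6 percentage points lower from compound 1 to compound 3 (within the scatter), so that change shows no clear effect. Nothing measured here explains this difference. Going by these compounds, whether a hydroxyl group, a fluorine atom or an amine at this position would match hydrogen or methoxy stays open. So does whether a longer chain, such as ethoxy, would be tolerated there.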